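The source may hold more compounds than are shown below. What is called first, only, known or untested is meant among the compounds shown, and "the series" means these compounds.

Measured so far in a functional assay with Alpha-1A adrenergic receptor (Homo sapiens) as the target, read by calcium flux; a lower number here means a smaller maximal response, a higher number a larger maximal response: compound 1 `Cc1n[nH]c(-c2ccccc2NCC2=NCCN2)n1` gives 87%; compound 2 `CCCn1nccc1-c1ccccc1NCC1=NCCN1` gives 59%; compound 3 `c1ccc(-c2nc[nH]n2)c(NCC2=NCCN2)c1` gives 135%.

Compound 3 stands highest of the three in this assay, beyond the scatter from both others. Compound 4 `Cn1nccc1-c1ccccc1NCC1=NCCN1` differs from compound 3 as follows: 1-methyl-1H-pyrazol-5-yl in place of 1H-1,2,4-triazol-3-yl on an aromatic carbon. Going by the values given here, the one measured step at this position, a number 48 percentage points higher from compound 1 to compound 3 (beyond the scatter), is large and shows that the ring here matters. Among the compounds with values here, compound 2, which also carries a pyrazolyl ring here, sits well below compound 3 in this assay; no step between compound 2 and compound 4 is measured. A drop from compound 3 to compound 4 is therefore expected, of about a number 55 percentage points lower from compound 3 to compound 4 (beyond the scatter). Compound 4 is estimated at 80% in this assay, with a range of 50% to 115%.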

Compound 4, largest response reached (reported as maximal response), in percent of the reference or control that the assay uses: 108%
Beside the measured number, compound 4's estimate is 28 percentage points below it, within the range that was stated.
By their numbers in this assay, from the lowest: compound 2; then compound 1; then compound 4; then compound 3.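

In this assay a pyrazolyl ring at this place does not by itself hold the response down: the methyl group in place of the propyl group gives a number 49 percentage points higher from compound 2 to compound 4 (beyond the scatter) on the shared core. The 1-methyl-1H-pyrazol-5-yl group also gives a number 21 percentage points higher from compound 1 to compound 4 (beyond the scatter) against the methylated triazolyl ring, while a number 27 percentage points lower from compound 3 to compound 4 (beyond the scatter) leaves the 1H-1,2,4-triazol-3-yl group on top of the four. No supporting data bear on why these steps arise.

Open, on these data alone, is how an ethyl or 2-hydroxyethyl group on the same aromatic nitrogen would read. Also open, as far as these compounds go, is how the pyrazolyl ring with a hydrogen on that nitrogen would compare with compound 3.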